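Benzyloxy in place of bromo: cytotoxicity outlook

The compounds below may be only part of what the source reports. "The series", "measured", "known", "first", "only" and "open" are said of these compounds alone.

In an ADME assay on HEK293 cells (Homo sapiens) for cytotoxicity, read by MTT assay, with a stated time of 24 h (a higher number here means a weaker inhibitor, a lower number a stronger inhibitor), compound 2 `Cc1cc(O)c(C(=O)/C=C/c2ccc(OCc3ccccc3)cc2)c(-c2ccc(Br)cc2)c1C(=O)/C=C/c1ccc(OCc2ccccc2)cc1` gives 25000 nM. Within the data shown here, only two numbers are in hand; the other belongs to compound 1 `Cc1cc(O)c(C(=O)/C=C/c2ccc(OCc3ccccc3)cc2)c(-c2ccccc2)c1C(=O)/C=C/c1ccc(OCc2ccccc2)cc1`, which in this assay gives 30000 nM, and the gap between the two is within the scatter. Among the measured compounds shown here, the single measured step, a 1.2-fold lower number from compound 1 to compound 2 (0.08 log units; within the scatter), came from bromo in place of hydrogen on an aromatic carbon and changed nothing beyond the scatter. Compound 3 `Cc1cc(O)c(C(=O)/C=C/c2ccc(OCc3ccccc3)cc2)c(-c2ccc(OCc3ccccc3)cc2)c1C(=O)/C=C/c1ccc(OCc2ccccc2)cc1` differs from compound 2 by benzyloxy in place of bromo on an aromatic carbon. For the measured compounds named here, the entering group is the same benzyloxy that the shared core of compound 2 already carries twice, but no measured pair shows its entry at this position, so the only guide is the small step at the same aromatic carbon. The step of no change at the digits printed from compound 2 to compound 3 (within the scatter) is therefore expected to stay within the scatter. Compound 3 is estimated to give about 25000 nM in this assay, with a range from 12000 nM to 50000 nM.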

Compound 3, half-maximal inhibitory concentration: 30000 nM
Compound 3: the middle estimate sits 1.2-fold (0.08 log units) below what was measured; low and high end bracket the measured number.
By their numbers in this assay, from the lowest: compounds 2, 1 and 3 (each within the scatter of the next).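

Benzyloxy in place of bromo at this aromatic carbon, para to a large group, gives a 1.2-fold higher number from compound 2 to compound 3 (0.08 log units; within the scatter) and benzyloxy in place of hydrogen gives no change at the digits printed from compound 1 to compound 3 (within the scatter) so neither new step lies beyond the scatter. Across compound 1, compound 2 and compound 3, the reading in this assay therefore stays within the scatter whether this carbon carries hydrogen, a single bromine atom or a benzyloxy group with eight heavy atoms and its own aromatic ring. Nothing available explains this flat reading.

On these data alone, whether an amine or a carboxylic acid at this carbon would also stay within the scatter remains open. Also open, as far as these compounds go, is whether changing either benzyloxy group on the shared core, for example to a shorter methoxy group, would shift the number beyond the scatter.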